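The compounds below may be only part of what the source reports. "The series", "measured", "known", "first", "only" and "open" are said of these compounds alone.

Three compounds were measured in a functional assay on ECa-109 cells for inhibition, with ECa-109 cell line (Homo sapiens) as the target, read by sulforhodamine B assay; on this read-out higher numbers stand for weaker inhibition and lower numbers for stronger inhibition:

Compound 1 `Cc1ccc(NC2=CC(=O)c3nc4n(c3C2=O)[C@H]2OC[C@@H](O)[C@H]2OC4)cc1`: 3480 nM
Compound 2 `COc1cccc(NC2=CC(=O)c3nc4n(c3C2=O)[C@H]2OC[C@@H](O)[C@H]2OC4)c1`: 7620 nM
Compound 3 `O=C1C=C(N2CCCCC2)C(=O)c2c1nc1n2[C@H]2OC[C@@H](O)[C@H]2OC1`: > 8000 nM

Compound 3 sits at the limit of > 8000 nM in this assay, at which 1 of the 3 values shown sits, so only a limit and no number is known for it. Compound 4 `O=C1C=C(N2CCC2)C(=O)c2c1nc1n2[C@H]2OC[C@@H](O)[C@H]2OC1` is made from compound 3 by one change: azetidin-1-yl in place of piperidin-1-yl on a double-bonded ring carbon. Among the compounds with values here, no measured step alters the ring size of such a cyclic amine. The steps that touch this position are an at least 2.2-fold higher number from compound 1 to compound 3 (0.36 log units; beyond the scatter) and an at least 1.0-fold higher number from compound 2 to compound 3 (0.02 log units; that floor lies within the scatter), and both only place the piperidine compound at the weak end. Compound 4 is therefore expected to show no step beyond the scatter, a step that the limit leaves unreadable from compound 3 to compound 4, and to stay at the weak end. Compound 4 is estimated at 9000 nM, within 4000 nM to 20000 nM.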

Compound 4, half-maximal inhibitory concentration: > 16000 nM
Compound 4 ended at the assay's limit; the forecaster's own chance of this, stated with the estimate: 60%; at least 1.7-fold (0.24 log units) between middle value and limit.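

Compound 4 gives only a limit of the assay: the limit of > 16000 nM in this assay, at which 1 of the 4 values shown sits.

In this assay, a cyclic amine at this position now falls clearly behind both arylamino compounds, with an at least 2.0-fold higher number from compound 2 to compound 4 (0.32 log units; beyond the scatter) and an at least 4.5-fold higher number from compound 1 to compound 4 (0.66 log units; beyond the scatter); compound 3 had shown this only against compound 1. Shrinking the ring to azetidin-1-yl therefore brings no sign of regained inhibition, although the step between the two cyclic amines cannot be read.

Going by these compounds, it remains open how weak either cyclic amine really is. On these data alone, it is also open whether a pyrrolidine ring or a benzylamine would behave like these cyclic amines or like the arylamino compounds.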